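Inverting the stereocentre of a potent benzyloxybenzyl amide

This account rests on a few compounds, and the source may have more. Where it says the series, first, only, none or still open, it means among the compounds named here.

Measured compounds:
compound 1, `NC(=O)[C@H](CO)NCc1ccc(OCc2ccc(Cl)cc2)cc1`, 1100 nM
compound 2, `NC(=O)[C@H](CO)NCc1ccc(OCc2cccc(Cl)c2)cc1`, 43 nM

Going by the values given here, in an assay on mitochondria for inhibition of Amine oxidase [flavin-containing] B (Rattus norvegicus) (a higher number here means a weaker inhibitor, a lower number a stronger inhibitor), compound 2 gives the lowest number of the two, with compound 1 the nearest at 1100 nM; the only measured step, a 26-fold lower number from compound 1 to compound 2 (1.41 log units; beyond the scatter), concerns a change on the chlorophenyl ring and nothing else.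

Compound 3, `NC(=O)[C@@H](CO)NCc1ccc(OCc2cccc(Cl)c2)cc1`, differs from compound 2 as follows: the two compounds have the same atoms and bonds and differ only in configuration as drawn: 1 of 1 stereo elements differ; a stereocentre at a saturated chain carbon is drawn S in compound 2 and R in compound 3. Among the compounds with values here, no measured step bears on a change of configuration, since compound 1 and compound 2 share the same drawn configuration and differ only in the chlorine position. The step of a 26-fold lower number from compound 1 to compound 2 (1.41 log units; beyond the scatter) therefore says nothing about what the inversion will do.

With nothing in the data on which to base a direction, the estimate for compound 3 in this assay is 300 nM, within a wide range from 40 nM to 3000 nM, which corresponds to an expected step of a 7.0-fold higher number from compound 2 to compound 3 (0.84 log units; beyond the scatter); this expectation rests on the value of compound 2, 43 nM, as the only anchor available.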

Compound 3, half-maximal inhibitory concentration: 110 nM
Estimate against measurement, compound 3: 2.7-fold (0.44 log units) above; the range from low to high includes it.
By their numbers in this assay, from the lowest: compound 2; then compound 3; then compound 1.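

In this assay the inversion of the stereocentre gives a 2.6-fold higher number from compound 2 to compound 3 (0.41 log units; beyond the scatter), so this position responds to configuration, with the drawn S form giving the lower number of the pair. That change is clearly smaller than a 26-fold lower number from compound 1 to compound 2 (1.41 log units; beyond the scatter) and, in this pair, inversion leaves the compound with a number in the same nanomolar range as its parent, so the position tolerates either configuration far better than a strict preference for one form would imply. The step can be assigned to the stereocentre alone, and the reason lies in the pair itself: the fact that compounds 2 and 3 differ only in the configuration as drawn.

The compounds shown leave open whether the same modest preference for the S form holds with the 4-chlorophenyl group, since the inversion is seen only with the 3-chlorophenyl group. They also leave open whether the size of the step depends on the groups attached to the stereocentre, for instance whether it would persist with a methyl in place of the hydroxymethyl or with a carboxylic acid in place of the primary amide.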